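Swapping the pendant aryl group on the shared core

The source may report more compounds than this note shows. Statements on the series, on what has been measured and on what is new or still open speak of the compounds shown alone.

For the measured compounds named here, compound 1 `COc1cc(-n2cnc3ccc(-c4ccc(C(F)(F)F)cc4)cc32)cc(OC)c1OC` gives 3390 nM in a functional assay on A549 cells (Homo sapiens) for antiproliferative activity, read by MTT assay, with a stated time of 72 h (a lower number here means a stronger inhibitor, a higher number a weaker inhibitor), the lowest of the two numbers so far. Compound 2 `COc1cc(-n2cnc3ccc(-c4cccc([N+](=O)[O-])c4)cc32)cc(OC)c1OC` gives 5410 nM in this assay; the step of a 1.6-fold higher number from compound 1 to compound 2 (0.20 log units; within the scatter) shows that exchanging one pendant aryl group for another left the read-out within the scatter. Compound 3 `COc1cc(-n2cnc3ccc(-c4ccc(Cl)cc4Cl)cc32)cc(OC)c1OC` has not yet been measured in this assay. It differs from compound 1 as follows: 2,4-dichlorophenyl in place of 4-(trifluoromethyl)phenyl on an aromatic carbon. The only measured step that bears on this kind of change is the one from compound 1 to compound 2, a 1.6-fold higher number from compound 1 to compound 2 (0.20 log units; within the scatter), which stayed within the scatter; no measured pair covers a 2,4-dichlorophenyl group, so nothing shown argues for a shift beyond the scatter. For compound 3 the expected step is a 1.0-fold higher number from compound 1 to compound 3 (0.01 log units; within the scatter), essentially no change. The estimate for compound 3 in this assay is 3500 nM, with a range from 1200 nM to 10000 nM.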

Compound 3, half-maximal inhibitory concentration: > 10000 nM
Compound 3 gave a limit, no number (the forecaster's own chance of this, stated with the estimate: 5%); middle value at least 2.8-fold (0.45 log units) away from the limit.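

Compound 3 gives a limit, not a number, in this assay: the limit of > 10000 nM in this assay, at which 1 of the 3 values shown sits.

For the compounds shown here, this position is not indifferent to the aryl group it carries: placing 2,4-dichlorophenyl there gives an at least 2.9-fold higher number from compound 1 to compound 3 (0.46 log units; beyond the scatter), whereas the only earlier step stayed within the scatter. Against the 3-nitrophenyl group the result is only a floor, an at least 1.8-fold higher number from compound 2 to compound 3 (0.26 log units; that floor lies within the scatter), so it sets no order between those two groups.

The compounds shown do not separate the contributions of the two chlorines of 2,4-dichlorophenyl, as no monochlorophenyl group stands among them, and how far the value of compound 3 lies past the limit stays unknown. As far as these compounds go, how an amine or a carboxylic acid on the pendant phenyl ring would read in this assay also remains open.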